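The source may hold more compounds than are shown below. What is called first, only, known or untested is meant among the compounds shown, and "the series" means these compounds.

Three compounds with the shared core of compound 1 `CCC(CC)n1c(-c2ccc(OCc3c(-c4c(Cl)cccc4Cl)noc3C(C)C)cc2)nc2ccc(C(=O)O)cc21` have been measured in an assay on isolated protein for agonist activity at Bile acid receptor (Homo sapiens), read by TR-FRET; on this read-out lower numbers stand for an effect already at smaller amounts and higher numbers for an effect only at larger amounts of compound. In this assay compound 1 gives 26.5 nM, compound 2 `CC(C)c1onc(-c2c(Cl)cccc2Cl)c1COc1ccc(-c2nc3ccc(C(=O)O)cc3n2Cc2ccc(F)cc2)cc1` gives 105 nM, and compound 3 `CCCn1c(-c2ccc(OCc3c(-c4c(Cl)cccc4Cl)noc3C(C)C)cc2)nc2ccc(C(=O)O)cc21` gives 96.4 nM. Compound 3 thus stands second highest of the three numbers, within the scatter of compound 2, and the only step beyond the scatter among these is the one from compound 1, where hydrogen replaced ethyl on the chain carbon bound to the aromatic nitrogen: a 3.6-fold higher number from compound 1 to compound 3 (0.56 log units; beyond the scatter). The step of a 4.0-fold higher number from compound 1 to compound 2 (0.60 log units; beyond the scatter) is of similar size, while a 1.1-fold lower number from compound 2 to compound 3 (0.04 log units; within the scatter) is within the scatter.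

Compound 4 `CC(C)c1onc(-c2c(Cl)cccc2Cl)c1COc1ccc(-c2nc3ccc(C(=O)O)cc3n2C2CC2)cc1` differs from compound 3 by cyclopropyl in place of propyl on an aromatic nitrogen. Among the measured compounds shown here, no measured step swaps a chain for a ring at this nitrogen. The nearest guide is compound 1, whose pentan-3-yl, branched at the carbon on the nitrogen, gave 26.5 nM; cyclopropyl also branches at that carbon, so a modest lower number is expected, a 1.6-fold lower number from compound 3 to compound 4 (0.21 log units; within the scatter). Compound 4 is therefore estimated at 60 nM, within 25 nM to 150 nM.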

Compound 4, half-maximal effective concentration: 117 nM
For compound 4 the middle estimate is 2.0-fold (0.29 log units) below the measured one, within the range that was stated.
By their numbers in this assay, from the lowest: compound 1; then compounds 3, 2 and 4 (each within the scatter of the next).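

In this assay, a ring in place of a chain of the same heavy-atom count at this aromatic nitrogen makes no difference that can be read, with a 1.2-fold higher number from compound 3 to compound 4 (0.08 log units; within the scatter), and cyclopropyl also stays within the scatter of 4-fluorobenzyl, with a 1.1-fold higher number from compound 2 to compound 4 (0.05 log units; within the scatter). Branching at the carbon on the nitrogen is therefore not enough to match compound 1, since compound 4 goes against that pattern and pentan-3-yl remains apart, with a 4.4-fold higher number from compound 1 to compound 4 (0.64 log units; beyond the scatter). Nothing available accounts for these numbers.

The compounds shown leave open whether the gain seen with pentan-3-yl needs both of its ethyl arms. An isopropyl or a cyclopentyl group on this nitrogen could place a number nearer to compound 1 or nearer to compound 3.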